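The compounds below may be only part of what the source reports. "The series", "measured", "known", "first", "only" and "open" are said of these compounds alone.

In a functional assay on MCF7 cells (Homo sapiens) for antiproliferative activity, read by MTT assay, with a stated time of 48 h (a higher number here means a weaker inhibitor, a lower number a stronger inhibitor), compound 1 (`COc1ccc(C(=O)/C=C/c2cccc(Cl)c2Oc2c([N+](=O)[O-])cc(C(F)(F)F)cc2[N+](=O)[O-])cc1`) gives 1.83 ug/mL, compound 2 (`O=C(/C=C/c1cccc(Cl)c1Oc1c([N+](=O)[O-])cc(C(F)(F)F)cc1[N+](=O)[O-])c1ccc(F)cc1`) gives 5.17 ug/mL and compound 3 (`O=C(/C=C/c1cc(Cl)cc(Cl)c1Oc1c([N+](=O)[O-])cc(C(F)(F)F)cc1[N+](=O)[O-])c1ccc(Br)cc1`) gives 2.6 ug/mL. Compound 3 thus lies within the scatter of both other compounds. Compound 4 (`O=C(/C=C/c1cccc(Cl)c1Oc1c([N+](=O)[O-])cc(C(F)(F)F)cc1[N+](=O)[O-])c1ccc(Br)cc1`) differs from compound 3 by one change: hydrogen in place of chloro on an aromatic carbon. This is hydrogen in place of chloro on an aromatic carbon, and compounds 1 and 2 also carry hydrogen at that carbon. Going by the values given here, no measured pair isolates this change, however. Among the compounds with values here, the only measured step, fluoro in place of methoxy on an aromatic carbon, is a 2.8-fold higher number from compound 1 to compound 2 (0.45 log units; beyond the scatter). It lies elsewhere in the molecule and is modest, so it shows only how far a single replacement has moved a value in this small set. No shift beyond the scatter is therefore expected, and no direction can be favoured with confidence. The estimated change is a 1.1-fold higher number from compound 3 to compound 4 (0.03 log units; within the scatter). For compound 4 the expected value is 2.8 ug/mL, with an estimated range from 1.2 ug/mL to 6.5 ug/mL.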

Compound 4, half-maximal inhibitory concentration: 1.41 ug/mL
For compound 4 the middle estimate is 2.0-fold (0.30 log units) above the measured one, within the range that was stated.
By their numbers in this assay, from the lowest: compounds 4, 1, 3 and 2 (each within the scatter of the next, the first and the last beyond it).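

Going by these compounds alone, this gives the first measured pair for hydrogen in place of chloro at this carbon: in this assay the change is a 1.8-fold lower number from compound 3 to compound 4 (0.27 log units; within the scatter), so the second chloro group has no effect that can be told from the scatter. With hydrogen at that carbon, the substituent on the other aromatic ring can also be compared: bromo in place of fluoro gives a 3.7-fold lower number from compound 2 to compound 4 (0.56 log units; beyond the scatter), a modest step beyond the scatter, whereas bromo in place of methoxy gives a 1.3-fold lower number from compound 1 to compound 4 (0.11 log units; within the scatter), which stays within it. Nothing available explains these steps.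

The compounds shown leave open how an amine or a carboxylic acid would behave at the carbon that carried the chloro group. They also do not show whether either group would move the value beyond the scatter there.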